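The compounds below may be only part of what the source reports. "The series", "measured", "known", "first", "only" and "open" are said of these compounds alone.

Compound 1 `C/N=C(\NC#N)Nc1cccnc1` carries a methyl on a double-bonded nitrogen of the shared core. In a functional assay on the whole organism (blood, strain Wistar-Okamoto) with Rattus norvegicus as the target, with a stated time of 5 days (a higher number here means that more compound is needed for the effect, a lower number that less compound is needed), compound 1 gives only a limit, > 50 mg/kg. Compound 2 `CCC(CC)/N=C(\NC#N)Nc1cccnc1` gives 20 mg/kg in this assay, and compound 3 `N#CN/C(=N\C1CCCC1)Nc1cccnc1` gives 20 mg/kg. The two steps from compound 1, an at least 2.5-fold lower number from compound 1 to compound 2 (0.39 log units; beyond the scatter) and an at least 2.5-fold lower number from compound 1 to compound 3 (0.39 log units; beyond the scatter), each put a larger group in place of the methyl and each count as at least modest; between the two larger groups, no change at the digits printed from compound 2 to compound 3 (within the scatter). Compound 4 `CCN(CC)CC/N=C(\NC#N)Nc1cccnc1` differs from compound 1 by (diethylamino)methyl in place of hydrogen on a saturated chain carbon bound to a double-bonded nitrogen. This change likewise enlarges what sits on that nitrogen, and the two measured steps are taken as its guide. Compound 4 is expected to need a lower dose than compound 1, a step of an at least 2.5-fold lower number from compound 1 to compound 4 (0.39 log units; beyond the scatter). The starting point is uncertain, as compound 1 stands only at the limit of > 50 mg/kg in this assay, at which 1 of the 3 values shown sits. Compound 4 is therefore estimated at 20 mg/kg, between 8 mg/kg and 50 mg/kg.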

Compound 4, minimum effective dose: > 8 mg/kg
Compound 4 gave a limit, no number; the forecaster's own chance of this, stated with the estimate: 30%; the middle value lies beyond the limit too.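

Compound 1 and compound 4 each stand only at a limit, so the step between them cannot be read. The compounds shown leave open whether (diethylamino)methyl in place of hydrogen changes the dose needed at all.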